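The source may report more compounds than this note shows. Statements on the series, on what has been measured and on what is new or still open speak of the compounds shown alone.

Three compounds of this series have numbers in an assay on isolated protein for inhibition of DNA topoisomerase 1 (Homo sapiens), with a stated time of 30 min, tested at 100 uM; on this read-out lower numbers stand for a weaker effect and higher numbers for a stronger effect at the one concentration tested. Compound 1 `Oc1cccc(-c2cc(-c3ccsc3)cc(-c3cccc(O)c3)n2)c1` gives 59.2%. Compound 2 `Oc1ccc(-c2cc(-c3ccsc3)cc(-c3cccc(O)c3)n2)cc1` gives 17.1%. Compound 3 `Oc1cccc(-c2cc(-c3ccoc3)cc(-c3cccc(O)c3)n2)c1` gives 44.2%. Compound 4 `Oc1ccc(-c2cc(-c3ccoc3)cc(-c3cccc(O)c3)n2)cc1` has not been measured in this assay.

Compound 3 stands second of the three; compound 1 sits higher and compound 2 sits lower, both beyond the scatter.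

The change from compound 1 to compound 2 is 4-hydroxyphenyl in place of 3-hydroxyphenyl on an aromatic carbon. It made a large step: a number 42.1 percentage points lower from compound 1 to compound 2 (beyond the scatter). The cores of compound 1 and compound 3 differ by furan-3-yl in place of thiophen-3-yl on an aromatic carbon, with a modest step: a number 15 percentage points lower from compound 1 to compound 3 (beyond the scatter).

The change from compound 3 to compound 4 is 4-hydroxyphenyl in place of 3-hydroxyphenyl on an aromatic carbon. For the measured compounds named here, it is the same kind of change as the one from compound 1 to compound 2, not the same: around the place, the first change is meta to a thiophen-3-yl group, the second is meta to a furan-3-yl group.

Going by the values given here, for compound 4 a step of about the size of the earlier one is expected, a number 36.2 percentage points lower from compound 3 to compound 4 (beyond the scatter), because a number 42.1 percentage points lower from compound 1 to compound 2 (beyond the scatter) is the only measured instance of this change, and the core swap gave only the modest a number 15 percentage points lower from compound 1 to compound 3 (beyond the scatter). The estimate for compound 4 is 8%, expected to lie between 0% and 25%. One measured pair is a thin basis; the estimate is tentative.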

Compound 4, a percentage reported as inhibition, at one concentration (the size of the read-out at that concentration, not a potency): 37.4%
For compound 4 the middle estimate is 29.4 percentage points below the measured one, outside the stated range (above it).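

In this assay, 4-hydroxyphenyl in place of 3-hydroxyphenyl gives a number 6.8 percentage points lower from compound 3 to compound 4 (within the scatter), so the large step seen with the thiophen-3-yl group does not carry over to the core with the furan-3-yl group: the same change on two cores in this assay, a number 42.1 percentage points lower (beyond the scatter) from compound 1 to compound 2 and a number 6.8 percentage points lower (within the scatter) from compound 3 to compound 4, 35.3 percentage points apart, beyond the scatter of two such steps

The reverse reading gives the same result, as furan-3-yl in place of thiophen-3-yl gives a number 20.3 percentage points higher from compound 2 to compound 4 (beyond the scatter), which is opposite in direction to the step between the two compounds that carry only 3-hydroxyphenyl groups: the same change on two cores in this assay, a number 15 percentage points lower (beyond the scatter) from compound 1 to compound 3 and a number 20.3 percentage points higher (beyond the scatter) from compound 2 to compound 4, 35.3 percentage points apart, beyond the scatter of two such steps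

These two comparisons rest on the same four compounds and are one observation seen from two sides: the effect of each change depends on the group at the other place, so neither step can be transferred to a new core by simple addition, though the data do not show why this happens, whether it extends beyond these four compounds, or how potency behaves, since the read-out comes from one concentration.

The compounds shown leave open whether this dependence persists when an amine or a carboxylic acid stands in place of the hydroxyl on the phenyl groups. They also leave open what happens when a longer chain replaces the furan-3-yl or thiophen-3-yl group.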